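The compounds below may be only part of what the source reports. "The series", "measured", "known", "first", "only" and "open" are said of these compounds alone.

Two compounds have so far been run through an in vivo ADME assay on the whole organism (strain CD-1) for pharmacokinetics, with Mus musculus as the target; on this read-out lower numbers stand for slow clearance and higher numbers for fast clearance. Compound 1 `CCCS(=O)(=O)Nc1ccc(Cl)c(C(=O)Nc2cnc3[nH]nc(OC)c3c2)c1F` gives 1 mL/min/kg in this assay, and compound 2 `CCCS(=O)(=O)Nc1ccc(F)c(C(=O)Nc2cnc3[nH]ncc3c2)c1F` gives 15 mL/min/kg. Compound 2 therefore stands highest of the two numbers; its nearest neighbour is compound 1, whose number is lower by an amount well beyond the scatter of repeated measurements. Among the compounds with values here, no pair of measured compounds differs in only one place, so no measured step size can be quoted. Compound 3 `CCCS(=O)(=O)Nc1ccc(Cl)c(C(=O)Nc2cnc3[nH]ncc3c2)c1F` has not yet been measured. It differs from compound 2 by chloro in place of fluoro on an aromatic carbon. Compound 1 also carries chloro there but differs from compound 3 in a second place as well, so it is only a rough guide. A moderate drop in clearance is expected, given that compound 1 gives 1 mL/min/kg. The expected step in this assay is a 3.0-fold lower number from compound 2 to compound 3 (0.48 log units; beyond the scatter). Compound 3 is estimated at 5 mL/min/kg, with a range from 2 mL/min/kg to 14 mL/min/kg.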

Compound 3, clearance: 2.3 mL/min/kg
Compound 3: middle estimate off by 2.2-fold (0.34 log units), on the high side, and the stated range covers the measured number.
By their numbers in this assay, from the lowest: compound 1; then compound 3; then compound 2.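

In this assay, the change from fluoro to chloro on the aromatic carbon para to a (propylsulfonyl)amino group now has a measured size: a 6.5-fold lower number from compound 2 to compound 3 (0.81 log units; beyond the scatter) and lies beyond the scatter, so a swap of one atom at this position is enough to move clearance. Within the data shown here, the methoxy position can also be read on its own for the first time, since hydrogen in place of methoxy on an aromatic carbon gives a 2.3-fold higher number from compound 1 to compound 3 (0.36 log units; beyond the scatter) and also lies beyond the scatter. No measurement at hand explains why either change alters clearance.

Going by these compounds, whether bromo or trifluoromethyl at the chloro position would give lower or higher clearance remains open. On these data alone, it is also open whether ethoxy or an amine in place of methoxy would give a similar step.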